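This account rests on a few compounds, and the source may have more. Where it says the series, first, only, none or still open, it means among the compounds named here.

Compound 1 `O=C(Nc1ccccc1)Nc1nc(NC2CC2)cc(Sc2c[nH]c3ccccc23)n1` is the starting point of this small set. In a functional assay on HepG2 cells (Homo sapiens) for inhibition, with a stated time of 72 h (a higher number here means a weaker inhibitor, a lower number a stronger inhibitor), compound 1 gives 14300 nM. Compound 2 `O=C(Nc1ccccc1)Nc1nc(Sc2c[nH]c3ccccc23)cc(N2CCN(c3ccccn3)CC2)n1` carries the change (4-(pyridin-2-yl)piperazin-1-yl in place of cyclopropylamino on an aromatic carbon), and in this assay compound 2 gives 8930 nM, a step of a 1.6-fold lower number from compound 1 to compound 2 (0.20 log units; within the scatter). Compound 3 `Cc1cc(Cl)ccc1NC(=O)Nc1nc(NC2CC2)cc(Sc2c[nH]c3ccccc23)n1` differs from compound 1 by 4-chloro-2-methylphenyl in place of phenyl on an amide-type nitrogen, and in this assay compound 3 gives 9740 nM, a step of a 1.5-fold lower number from compound 1 to compound 3 (0.17 log units; within the scatter). Compound 4 `Cc1cc(Cl)ccc1NC(=O)Nc1nc(Sc2c[nH]c3ccccc23)cc(N2CCN(c3ccccn3)CC2)n1` is not yet measured; it differs from compound 3 by 4-(pyridin-2-yl)piperazin-1-yl in place of cyclopropylamino on an aromatic carbon. For the measured compounds named here, this is the same kind of change as the one from compound 1 to compound 2, though the place is meta to a (phenylcarbamoyl)amino group in compound 1 and meta to a large group in compound 3. Because a 1.6-fold lower number from compound 1 to compound 2 (0.20 log units; within the scatter) was within the scatter, the step from compound 3 to compound 4 is expected to be about a 1.6-fold lower number from compound 3 to compound 4 (0.20 log units; within the scatter). Compound 4 is therefore estimated at 6200 nM, with a range from 2500 nM to 15000 nM.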

Compound 4, half-maximal inhibitory concentration: 7640 nM
Compound 4: middle estimate off by 1.2-fold (0.09 log units), on the low side; the measured number falls inside the stated range.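

Carrying 4-(pyridin-2-yl)piperazin-1-yl in place of cyclopropylamino from one core to the other gave no detectable difference between the two steps: the same change on two cores in this assay, a 1.6-fold lower number (0.20 log units; within the scatter) from compound 1 to compound 2 and a 1.3-fold lower number (0.11 log units; within the scatter) from compound 3 to compound 4, 1.3-fold (0.10 log units) apart, within the scatter of two such steps

The same holds for 4-chloro-2-methylphenyl in place of phenyl: the same change on two cores in this assay, a 1.5-fold lower number (0.17 log units; within the scatter) from compound 1 to compound 3 and a 1.2-fold lower number (0.07 log units; within the scatter) from compound 2 to compound 4, 1.3-fold (0.10 log units) apart, within the scatter of two such steps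

For the compounds shown here, with a 1.3-fold lower number from compound 3 to compound 4 (0.11 log units; within the scatter) and a 1.2-fold lower number from compound 2 to compound 4 (0.07 log units; within the scatter), both changes stay within the scatter on both cores in this assay, so the set shows only that neither change has a measurable effect on either core, not that a larger effect would carry across.

The compounds shown leave open whether a morpholine or a longer amine chain in place of cyclopropylamino would give a step beyond the scatter. They also leave open what a nitrile on the phenyl ring would do.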